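The source may report more compounds than this note shows. Statements on the series, on what has been measured and on what is new or still open speak of the compounds shown alone.

Compound 1 `O=C(/C=C/c1cccc(NC(=O)c2ccccc2Cl)c1)c1nc2ccccc2[nH]1`: 3690 nM in a functional assay on 143B cells (Homo sapiens) for antiproliferative activity, read by MTT assay, with a stated time of 48 h; on this read-out higher numbers stand for weaker inhibition and lower numbers for stronger inhibition
Compound 2 `COc1cccc(C(=O)Nc2cccc(/C=C/C(=O)c3nc4ccccc4[nH]3)c2)c1`: 4610 nM
Compound 3 `COc1ccc(C(=O)Nc2cccc(/C=C/C(=O)c3nc4ccccc4[nH]3)c2)cc1`: 6330 nM

All three compounds share one core and differ only in the aryl ring on the amide carbonyl. Compound 3 carries the highest of the three numbers, but its gaps to the others are small: a 1.4-fold higher number from compound 2 to compound 3 (0.14 log units; within the scatter) and a 1.7-fold higher number from compound 1 to compound 3 (0.23 log units; within the scatter) both sit within the scatter, so no order among the three can be claimed.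

Compound 4 `Cc1cccc(S(=O)(=O)Nc2cccc(/C=C/C(=O)c3nc4ccccc4[nH]3)c2)c1` introduces a different kind of change: (3-methylphenyl)sulfonyl in place of (4-methoxyphenyl)carbonyl on a nitrogen on an aromatic ring. Here the amide carbonyl itself gives way to a sulfonyl, and the ring substituent changes from methoxy to methyl.

For the measured compounds named here, none of the measured steps touches the carbonyl; each one only exchanged the aryl ring attached to it, and each was within the scatter: a 1.2-fold higher number from compound 1 to compound 2 (0.10 log units; within the scatter), a 1.7-fold higher number from compound 1 to compound 3 (0.23 log units; within the scatter), a 1.4-fold higher number from compound 2 to compound 3 (0.14 log units; within the scatter). They show that the series has so far been insensitive to the aryl ring, but they say nothing about swapping carbonyl for sulfonyl. Going by the values given here, with no direct precedent, the best guess is a step within the scatter, held with a wide range.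

Compound 4 is therefore expected to give about 6000 nM in this assay, between 1800 nM and 20000 nM, which means an expected step of a 1.1-fold lower number from compound 3 to compound 4 (0.02 log units; within the scatter).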

Compound 4, half-maximal inhibitory concentration: 791 nM
Beside the measured number, compound 4's estimate is 7.6-fold (0.88 log units) above it; measured number outside the range, below it.
By their numbers in this assay, from the lowest: compound 4; then compounds 1, 2 and 3 (each within the scatter of the next).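

Swapping the aryl ring on the amide carbonyl had left every step within the scatter, but replacing the whole carbonyl-linked group on the nitrogen with (3-methylphenyl)sulfonyl gives steps beyond the scatter in this assay: an 8.0-fold lower number from compound 3 to compound 4 (0.90 log units; beyond the scatter), a 5.8-fold lower number from compound 2 to compound 4 (0.77 log units; beyond the scatter) and a 4.7-fold lower number from compound 1 to compound 4 (0.67 log units; beyond the scatter). This shows that the group on this nitrogen can change the read-out, and compound 4 now stands apart as the strongest inhibitor of the four, since its steps to all the others lie beyond the scatter. No measurement shown here explains why this change lowers the number.

Compound 4 differs from the others in two ways at once, in the sulfonyl that replaces the carbonyl and in the methyl on its ring, so (3-methylphenyl)carbonyl and (4-methoxyphenyl)sulfonyl versions would be needed to tell which of the two carries the step. As far as these compounds go, it also remains open whether the sulfonyl keeps this effect with other groups on it, such as a 2-chlorophenyl ring, a plain methyl or a ring bearing an amine.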